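This account rests on a few compounds, and the source may have more. Where it says the series, first, only, none or still open, it means among the compounds named here.

Compound 1 `COc1ccc(C2=NN(c3ccccc3)C(c3ccc(C)cc3)C2S(=O)(=O)CC2=NCCO2)cc1` and compound 2 `COc1ccc(C2=NN(c3ccccc3)C(c3ccc(C)cc3)C2S(=O)(=O)CC2=NCCS2)cc1` share one core and differ only in the ring carried on the saturated chain carbon bound to a sulfonyl sulfur. In a functional assay, read by Griess assay, with a stated time of 150 min, tested at 50 ug/mL (on this read-out lower numbers stand for a weaker effect and higher numbers for a stronger effect at the one concentration tested), compound 1 gives 59.1%, while compound 2 gives 39.4%. The difference, (a group of 5 heavy atoms (3 carbon, 1 nitrogen, 1 oxygen; one five-membered non-aromatic ring with 2 hetero atoms) in place of a group of 5 heavy atoms (3 carbon, 1 nitrogen, 1 sulfur; one five-membered non-aromatic ring with 2 hetero atoms), on a saturated chain carbon bound to a sulfonyl sulfur), produced a step of a number 19.7 percentage points higher from compound 2 to compound 1 (beyond the scatter).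

Compound 3 `O=S(=O)(CC1=NCCS1)c1c(-c2ccccc2)noc1-c1ccccc1` is built on a different core; the difference between the two cores is not broken down here. In this assay compound 3 was reported as "not active" (no number reported), with no number given. Among the compounds with values here, compound 4 `O=S(=O)(CC1=NCCO1)c1c(-c2ccccc2)noc1-c1ccccc1` carries the same kind of change as the one from compound 2 to compound 1, namely (a group of 5 heavy atoms (3 carbon, 1 nitrogen, 1 oxygen; one five-membered non-aromatic ring with 2 hetero atoms) in place of a group of 5 heavy atoms (3 carbon, 1 nitrogen, 1 sulfur; one five-membered non-aromatic ring with 2 hetero atoms), on a saturated chain carbon bound to a sulfonyl sulfur), and the two place descriptions agree word for word.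

Since compound 3 starts without a measurable value, the earlier step from compound 2 to compound 1 gives only a rough guide, and a smaller gain is expected. Compound 4 is therefore estimated to reach about 18% in this assay, with a range expected from 0% to 38%, and a fair chance that it too is reported only as inactive.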

Compound 4, a percentage reported as activity, at one concentration (the size of the read-out at that concentration, not a potency): 56.7%
Beside the measured number, compound 4's estimate is 38.7 percentage points below it; measured number outside the range, above it.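

Compound 3 has no number in this assay and compound 4 gives 56.7%; no step can be read between them. The compounds shown leave open whether the ring change on the saturated chain carbon bound to a sulfonyl sulfur has the same size on both cores. Nothing shown here explains these results.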